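A Phenyl for Thiophen-3-yl Swap at One Position

A few compounds are considered here, and "the series" means these few. Any claim that something is new, unique, unknown or untested is made for them only; others in the source may bear on it.

The series shares a core carrying a 4-hydroxyphenyl group, with two further aryl groups around it. Compound 1 `Oc1ccc(-c2cc(-c3ccccc3)nc(-c3ccccc3Cl)c2)cc1` belongs to this set, but in an assay on isolated protein for inhibition of DNA topoisomerase 1 (Homo sapiens), with a stated time of 30 min, tested at 20 uM (a lower number here means a weaker effect, a higher number a stronger effect of the compound at the concentration tested), compound 1 is recorded as "not determined" (no result reported). Compound 2 `Oc1ccc(-c2cc(-c3ccc(Cl)cc3)nc(-c3cccnc3)c2)cc1` belongs to it too, and in this assay compound 2 is likewise recorded as "not determined" (no result reported). Compound 3 `Oc1ccc(-c2cc(-c3ccc(Cl)cc3)nc(-c3ccsc3)c2)cc1` is therefore the only member with a number: in this assay compound 3 gives 30.7%, and it stands alone on the numbers shown, with no other measured compound to compare it against.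

Compound 4 `Oc1ccc(-c2cc(-c3ccccc3)nc(-c3ccc(Cl)cc3)c2)cc1` is the next member and has not yet been measured in this assay. It differs from compound 3 in a single place: phenyl in place of thiophen-3-yl on an aromatic carbon. Within the data shown here, no step between measured compounds is known in this set, so the size of the effect of this exchange has to be guessed. The exchange is modest in scale, and a step from compound 3 to compound 4 in this assay is expected to be small, possibly none beyond the usual scatter, with a slight downward lean estimated as a number 3.7 percentage points lower from compound 3 to compound 4 (within the scatter).

For compound 4 the expected inhibition in this assay is 27%, estimated to fall between 8% and 48%.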

Compound 4, a percentage reported as inhibition, at one concentration (the size of the read-out at that concentration, not a potency): 55.2%
For compound 4 the middle estimate is 28.2 percentage points below the measured one, outside the stated range (above it).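

Putting phenyl in place of thiophen-3-yl on the aromatic carbon next to the ring nitrogen gives, in this assay, a number 24.5 percentage points higher from compound 3 to compound 4 (beyond the scatter), so this position is not indifferent to which aromatic ring it carries. Among these compounds, with only a single number available before, no such sensitivity could be seen, and it now rests on this one pair of compounds, with phenyl giving the higher inhibition of the two groups at this place. The data shown offer nothing that accounts for the gain, and no measurement of any property of the two groups bears on it.

On these data alone, whether this position keeps or loses inhibition with something other than a plain aromatic ring, such as an amine, a carboxylic acid or a longer alkyl chain, stays open. As far as these compounds go, it is equally open whether a fluorine or a methoxy group on the phenyl itself would raise the inhibition further or lower it, and whether the gain seen here would hold on a different arrangement of the other two aryl groups.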